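Adding a nitrile to compound 3: what to expect

The compounds below may be only part of what the source reports. "The series", "measured", "known", "first", "only" and "open" are said of these compounds alone.

Compound 1 `O=C(N1CCCCC1)n1cccn1`: 750 nM
Compound 2 `CC(C)(C)OC(=O)N1CCN(C(=O)n2cc(C#N)cn2)CC1`: 55 nM
Compound 3 `O=C(NCCCCc1ccccc1)n1cccn1`: 290 nM

In an assay on isolated protein for inhibition of Fatty-acid amide hydrolase 1 (Rattus norvegicus), with a stated time of 3 h (on this read-out higher numbers stand for weaker inhibition and lower numbers for stronger inhibition), compound 3 stands second highest of the three numbers; its nearest neighbour is compound 1, a gap beyond the scatter, and its furthest is compound 2, further still. Compound 4 `N#Cc1cnn(C(=O)NCCCCc2ccccc2)c1` differs from compound 3 by cyano in place of hydrogen on an aromatic carbon. Among the compounds with values here, no measured pair shows this change on its own. What the other two values show is that compound 1, which lacks the nitrile, gives 750 nM in this assay, while compound 2, which carries one, gives 55 nM, though the two differ in more than one place. The expected step is a drop, a 9.7-fold lower number from compound 3 to compound 4 (0.99 log units; beyond the scatter), beyond the usual scatter. Compound 4 is therefore estimated at 30 nM, within a range from 8 nM to 120 nM.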

Compound 4, inhibition constant: 42 nM
The estimate for compound 4 lay 1.4-fold (0.15 log units) below the measured number; measured number inside the range.
By their numbers in this assay, from the lowest: compounds 4 and 2 (each within the scatter of the next); then compound 3; then compound 1.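

In this assay, cyano in place of hydrogen on an aromatic carbon, two ring bonds from the ring nitrogen, gives a 6.9-fold lower number from compound 3 to compound 4 (0.84 log units; beyond the scatter) with nothing else in the structure changed. Within the data shown here, the earlier compounds differed in more than one place, so this pair is the first to show the change on its own. Nothing at hand explains the size of this step. The compounds shown leave open whether the nitrile gives a like step on the core of compound 1, and whether a chlorine, a carboxylic acid or an amine on this aromatic carbon would match it.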